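The source may hold more compounds than are shown below. What is called first, only, known or untested is meant among the compounds shown, and "the series" means these compounds.

Series notes. Compound 1 `O=C(O[C@H]1C[C@H](n2cc(F)c(=O)[nH]c2=O)O[C@@H]1COP(=O)(O)Oc1ccccc1)c1ccccc1` carries phenyl on the oxygen and in a functional assay on U-118-MG cells (Homo sapiens) for cytotoxicity, read by MTT assay, with a stated time of 48 h (on this read-out higher numbers stand for weaker inhibition and lower numbers for stronger inhibition), gives 970 nM. Compound 2 `O=C(O[C@H]1C[C@H](n2cc(F)c(=O)[nH]c2=O)O[C@@H]1COP(=O)(O)Oc1cccnc1)c1ccccc1`, with pyridin-3-yl in place of phenyl on that oxygen, gives 920 nM in this assay. Compound 3 `O=C(O[C@H]1C[C@H](n2cc(F)c(=O)[nH]c2=O)O[C@@H]1COP(=O)(O)Oc1ccc2ncccc2c1)c1ccccc1`, with quinolin-6-yl there, gives 790 nM in this assay. Compound 2 therefore stands second highest of the three numbers, with compound 1 nearest and compound 3 furthest, and every gap is within the scatter. The steps are a 1.1-fold lower number from compound 1 to compound 2 (0.02 log units; within the scatter), a 1.2-fold lower number from compound 1 to compound 3 (0.09 log units; within the scatter) and a 1.2-fold lower number from compound 2 to compound 3 (0.07 log units; within the scatter).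

Compound 4 `C[n+]1cccc(OP(=O)([O-])OC[C@H]2O[C@@H](n3cc(F)c(=O)[nH]c3=O)C[C@@H]2OC(=O)c2ccccc2)c1` is not yet measured. It differs from compound 2 by a group of 11 heavy atoms (6 carbon, 1 nitrogen, 3 oxygen, 1 phosphorus; one six-membered aromatic ring with 1 hetero atom) in place of a group of 10 heavy atoms (5 carbon, 1 nitrogen, 3 oxygen, 1 phosphorus; one six-membered aromatic ring with 1 hetero atom), on an oxygen on a saturated carbon. Among the compounds with values here, no measured step covers this exact change. Within the data shown here, the steps that bear on it are the three exchanges of the aryl group on the same oxygen, and none of them moved the number in this assay beyond the scatter. On that basis no step beyond the scatter is expected in this assay in either direction. The expected step is a 1.0-fold lower number from compound 2 to compound 4 (0.01 log units; within the scatter). Compound 4 is estimated at 900 nM, with a range from 450 nM to 1800 nM.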

Compound 4, half-maximal inhibitory concentration: 3150 nM
Beside the measured number, compound 4's estimate is 3.5-fold (0.54 log units) below it; measured number outside the range, above it.
By their numbers in this assay, from the lowest: compounds 3, 2 and 1 (each within the scatter of the next); then compound 4.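

The aryl exchanges among phenyl, pyridin-3-yl and quinolin-6-yl left the number in this assay within the scatter, so the oxygen on a saturated carbon had looked tolerant of change. Within the data shown here, the group of 11 heavy atoms is the first to move the number beyond the scatter, towards weaker inhibition: a 3.4-fold higher number from compound 2 to compound 4 (0.53 log units; beyond the scatter), and a 3.2-fold higher number from compound 1 to compound 4 (0.51 log units; beyond the scatter). The counts show one more carbon and 0 hydrogen-bond donors in place of 1 for the step from compound 2, but no measurement shown explains why the number rises.

Going by these compounds, it remains open whether a longer chain in place of the added carbon would give a similar step. On these data alone, the effect of an amine or a carboxylic acid on the aromatic ring of this group also remains open.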